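A few compounds are considered here, and "the series" means these few. Any claim that something is new, unique, unknown or untested is made for them only; others in the source may bear on it.

In an ADME assay on HepG2 2.2.15 cells (Homo sapiens) for cytotoxicity (on this read-out lower numbers stand for higher toxicity in this test and higher numbers for lower toxicity in this test), the three compounds with results so far all sit at the untroubling end of the read-out. Compound 3 `CCCCCC(=O)Nc1ncc(C(Oc2ccc3cc(Br)ccc3c2)c2ccc(Cl)cc2)s1` carries a pentylcarbonyl on the nitrogen on its aromatic ring, and in this assay compound 3 gives > 50000 nM, which is a limit of the test rather than a measured number. Compound 1 `CC(C)(C)OC(=O)Nc1ncc(C(Oc2ccc(Br)cc2)c2ccc(Cl)cc2)s1` gives > 50000 nM in this assay, again a limit and not a number. Compound 2 `O=C(Nc1ncc(C(OCc2ccc(Cl)cc2)c2ccccc2)s1)c1cccs1` is recorded in this assay as "not toxic" (no number reported), with no number attached. So compound 3 stands at the limit of > 50000 nM in this assay, at which 2 of the 3 values shown sit, and no ordering among the three compounds can be drawn from this.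

Compound 4 `Cc1ccc(C)c(S(=O)(=O)Nc2ncc(C(Oc3ccc4cc(Br)ccc4c3)c3ccc(Cl)cc3)s2)c1` differs from compound 3 in one place: (2,5-dimethylphenyl)sulfonyl in place of pentylcarbonyl on a nitrogen on an aromatic ring. Among the measured compounds shown here, no step between two measured compounds is available to gauge what such a swap does in this assay. Compound 3 offers only > 50000 nM, a limit. The step of a number no higher from compound 3 to compound 4 (the limit leaves the size open) is therefore expected to stay within the usual scatter, with no direction favoured. For compound 4 the estimated value in this assay is 50000 nM, with a range from 15000 nM to 150000 nM, and a fair chance that the test once more reports only a limit.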

Compound 4, half-maximal cytotoxic concentration: > 50000 nM
Compound 4: a limit, no number; the forecaster's own chance of this, stated with the estimate: 65%; the middle value lies on the limit itself.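

Compound 3 and compound 4 each give only a limit in this assay, not a number, and no step can be read from this swap on the nitrogen. Both stand with most of the compounds shown: the limit of > 50000 nM in this assay, at which 3 of the 4 values shown sit.

Going by these compounds, whether the group on that nitrogen changes the read-out of this assay at all stays open.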